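Swapping a carboxy hydrogen for methyl in growth inhibition

A few compounds are considered here, and "the series" means these few. Any claim that something is new, unique, unknown or untested is made for them only; others in the source may bear on it.

In a functional assay on OVCAR-3 cells (Homo sapiens) for antiproliferative activity (a higher number here means a weaker inhibitor of growth, a lower number a stronger inhibitor of growth), compound 1 `CCCCCCNC(=O)c1cc(C#Cc2cc(OC)ccc2OC)ccc1OC` gives > 100000 nM as a limit and not a number. Going by the values given here, compound 2 `COc1ccc(OC)c(C#Cc2ccc(OC)c(C(=O)O)c2)c1` carries hydroxy in place of hexylamino on a carbonyl carbon and gives 24400 nM as the only exact number so far. Among the compounds with values here, the step of an at least 4.0-fold lower number from compound 1 to compound 2 (0.61 log units; beyond the scatter) lies beyond the scatter and is the only measured step that bears on what follows. Compound 3 `COC(=O)c1cc(C#Cc2cc(OC)ccc2OC)ccc1OC` differs from compound 2 by methyl in place of hydrogen on an oxygen next to a carbonyl group with carboxy going to methoxycarbonyl. That measured step replaced a different group on the same carbonyl carbon, so it gives no firm direction here. The step of a 1.2-fold higher number from compound 2 to compound 3 (0.09 log units; within the scatter) in this assay is therefore expected to stay within the scatter, though with wide uncertainty. Compound 3 is estimated at 30000 nM as a middle value, with an expected range from 8000 nM to 100000 nM for repeated measurements.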

Compound 3, concentration for 50% growth inhibition: 13600 nM
For compound 3 the middle estimate is 2.2-fold (0.34 log units) above the measured one; the range from low to high includes it.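

Methyl in place of hydrogen on an oxygen next to a carbonyl group leaves growth inhibition in this assay unresolved, with a 1.8-fold lower number from compound 2 to compound 3 (0.25 log units; within the scatter), so the carboxy hydrogen is not needed for the level seen with compound 2. With hexylamino exchanged for methoxy, the step is an at least 7.3-fold lower number from compound 1 to compound 3 (0.86 log units; beyond the scatter), which leaves the two compounds without hexylamino apart from compound 1 but not apart from each other. Compound 1 stands at a limit and not a number, so this step has a bound and no exact size: the limit of > 100000 nM in this assay, at which 1 of the 3 values shown sits.

As far as these compounds go, whether an unsubstituted amino group, or a chain shorter than hexylamino, on that carbonyl carbon would keep this level stays open. So does whether a longer ester such as ethoxycarbonyl would hold it.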